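Three measured esters and one awaiting its cytotoxicity value

The source may report more compounds than this note shows. Statements on the series, on what has been measured and on what is new or still open speak of the compounds shown alone.

Compound 1, `CCN1CCN(CCC(=O)O[C@@H]2C[C@@H]3CC[C@@]2(C)C3(C)C)CC1`, gives 264000 nM in an ADME assay on HEK-293T cells (Homo sapiens) for cytotoxicity, read by MTT assay, with a stated time of 48 h; on this read-out higher numbers stand for lower toxicity in this test and lower numbers for higher toxicity in this test.
Compound 2, `CCN1CCN(CCCC(=O)O[C@@H]2C[C@@H]3CC[C@@]2(C)C3(C)C)CC1`, gives 131000 nM in this assay.
Compound 3, `CCOC(=O)N1CCN(CCC(=O)O[C@@H]2C[C@@H]3CC[C@@]2(C)C3(C)C)CC1`, gives 110000 nM in this assay.

Compound 1 and compound 2 both carry an ethyl on the ring nitrogen and differ in the part that links the ring to the ester; the difference between their two cores is not broken down here, and their two numbers in this assay lie within the scatter of each other. Compound 3 differs from compound 1 by a single change, (ethoxycarbonyl in place of ethyl on an amine nitrogen in a ring), and that change produced a 2.4-fold lower number from compound 1 to compound 3 (0.38 log units; beyond the scatter). Compound 2 and compound 3 likewise stand within the scatter of each other in this assay.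

Compound 4, `CCOC(=O)N1CCN(CCCC(=O)O[C@@H]2C[C@@H]3CC[C@@]2(C)C3(C)C)CC1`, has not yet been measured. For the measured compounds named here, it differs from compound 2 by ethoxycarbonyl in place of ethyl on an amine nitrogen in a ring, which is the same change as the one from compound 1 to compound 3: the group that leaves, the group that enters and the place around it are described in the same words. A single measured step is therefore the whole basis for what can be expected. If the change on the core of compound 2 behaves as it did on the core of compound 1, the expected step for compound 4 is a 2.4-fold lower number from compound 2 to compound 4 (0.38 log units; beyond the scatter), kept broad because a 2.4-fold lower number from compound 1 to compound 3 (0.38 log units; beyond the scatter) was seen only once. Compound 4 is accordingly estimated at 55000 nM, with a range from 28000 nM to 110000 nM.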

Compound 4, half-maximal cytotoxic concentration: 60400 nM
For compound 4 the middle estimate is 1.1-fold (0.04 log units) below the measured one, and the stated range covers the measured number.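

In this assay, ethoxycarbonyl in place of ethyl on an amine nitrogen in a ring gives a 2.2-fold lower number from compound 2 to compound 4 (0.34 log units; beyond the scatter), and this step can be set beside the earlier one: the same change on two cores in this assay, a 2.4-fold lower number (0.38 log units; beyond the scatter) from compound 1 to compound 3 and a 2.2-fold lower number (0.34 log units; beyond the scatter) from compound 2 to compound 4, 1.1-fold (0.04 log units) apart, within the scatter of two such steps. The change thus lowered the number by an amount that cannot be told apart on the core of compound 1 and on the core of compound 2, so in these two cases its size held when the part linking the ring to the ester differed. This rests on just two pairs in a single test, so it does not establish a rule for the whole series, and it does not show what lies behind the lower number or whether the step would hold in any other kind of measurement.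

The compounds shown leave open whether the step would stay the same with a still longer chain linking the ring to the ester, or with an amide in place of the ester. They also leave open how other groups on the same ring nitrogen, such as a methyl, an acetyl or a benzyl, would compare with ethyl and ethoxycarbonyl.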